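Cytotoxicity of a thiazole–pyrimidinone pair on kidney cells

The source may report more compounds than this note shows. Statements on the series, on what has been measured and on what is new or still open speak of the compounds shown alone.

Three compounds share one core and were tested in an ADME assay on HEK293 cells (Homo sapiens) for cytotoxicity, read by MTT assay, with a stated time of 48 h; on this read-out lower numbers stand for stronger inhibition and higher numbers for weaker inhibition. Compound 2 `COc1ccc(-c2nc(SCC(=O)c3sc(-c4ccccc4)nc3C)[nH]c(=O)c2C#N)cc1OC` gives 91800 nM in this assay. Compound 1 `Cc1nc(-c2ccc(Cl)cc2)sc1C(=O)CSc1nc(-c2ccc(Cl)c(Cl)c2)c(C#N)c(=O)[nH]1` gives 46900 nM in this assay, and the two numbers lie within the scatter of each other, so neither can be called the weaker or the stronger. For compound 3 `COc1ccc(-c2nc(SCC(=O)c3sc(-c4ccc(Cl)cc4)nc3C)[nH]c(=O)c2C#N)cc1OC` the entry in this assay reads "not determined" (no result reported), so no number is available for it.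

Compound 4 `Cc1nc(-c2ccccc2)sc1C(=O)CSc1nc(-c2ccc(Cl)c(Cl)c2)c(C#N)c(=O)[nH]1` has not been measured. It differs from compound 2 in one place: 3,4-dichlorophenyl in place of 3,4-dimethoxyphenyl on an aromatic carbon. Compound 1 already carries the same 3,4-dichlorophenyl group and gives 46900 nM in this assay, a number within the scatter of compound 2. Within the data shown here, with no step of this kind measured directly, the expectation is a change from compound 2 to compound 4 of a 1.5-fold lower number from compound 2 to compound 4 (0.18 log units; within the scatter), which is no more than the scatter. Compound 4 is therefore estimated to give 60000 nM in this assay, with a range from 25000 nM to 150000 nM.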

Compound 4, half-maximal inhibitory concentration: 85100 nM
For compound 4 the middle estimate is 1.4-fold (0.15 log units) below the measured one; low and high end bracket the measured number.
By their numbers in this assay, from the lowest: compounds 1, 4 and 2 (each within the scatter of the next).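

In this assay, putting 3,4-dichlorophenyl in place of 3,4-dimethoxyphenyl on this aromatic carbon gives a 1.1-fold lower number from compound 2 to compound 4 (0.03 log units; within the scatter) and so shows no readable effect of this exchange at the position ortho to a cyano group. Hydrogen in place of chloro on an aromatic carbon elsewhere in the molecule gives a 1.8-fold higher number from compound 1 to compound 4 (0.26 log units; within the scatter) and so also stays inside the usual scatter, which means that neither single change separates these compounds on this read-out. Nothing available bears on the reason for this result.

On these data alone, both groups compared at this position are substituted phenyl groups, so the outcome with an amine or a carboxylic acid there remains open. As far as these compounds go, compound 3 has no number, so the effect of the chloro group alongside 3,4-dimethoxyphenyl also remains open.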